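Carbonyl substituent changes at the piperidine amide position

A few compounds are considered here, and "the series" means these few. Any claim that something is new, unique, unknown or untested is made for them only; others in the source may bear on it.

Compound 1 `Cc1nc(S(C)(=O)=O)ccc1Oc1ncnc(OC2CCN(C(=O)OC(C)(C)C#N)CC2)c1F`: 1320 nM
Compound 2 `Cc1nc(S(C)(=O)=O)ccc1Oc1ncnc(OC2CCN(C(=O)SC3CCC3)CC2)c1F`: 77.4 nM

Among the compounds with values here, in a functional assay on isolated protein for inhibition of Glucose-dependent insulinotropic receptor (Rattus norvegicus), read by HTRF and cAMP accumulation (a higher number here means that more compound is needed for the effect, a lower number that less compound is needed), compound 2 gives 77.4 nM, the lowest of the two numbers so far; the nearest is compound 1 at 1320 nM. The next compound, compound 3 `Cc1nc(S(C)(=O)=O)ccc1Oc1ncnc(OC2CCN(C(=O)C(F)(F)F)CC2)c1F`, keeps the shared core and changes the carbonyl substituent: trifluoromethyl in place of cyclobutylsulfanyl on a carbonyl carbon. Within the data shown here, the only measured step that bears on this position is a 17-fold lower number from compound 1 to compound 2 (1.23 log units; beyond the scatter), which shows that the group on the carbonyl carbon can shift the number strongly. With no ring and no hydrogen-bond acceptor entering, a higher number is expected for compound 3, a step of a 6.5-fold higher number from compound 2 to compound 3 (0.81 log units; beyond the scatter). The estimate for compound 3 in this assay is 500 nM, within 120 nM to 2000 nM.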

Compound 3, half-maximal effective concentration: 880 nM
For compound 3 the middle estimate is 1.8-fold (0.25 log units) below the measured one, within the range that was stated.
By their numbers in this assay, from the lowest: compound 2; then compounds 3 and 1 (each within the scatter of the next).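

In this assay, the low number of compound 2 does not carry over to trifluoromethyl, with an 11-fold higher number from compound 2 to compound 3 (1.06 log units; beyond the scatter). Replacing 1-cyano-1-methylethoxy with trifluoromethyl gives a 1.5-fold lower number from compound 1 to compound 3 (0.18 log units; within the scatter), so compound 1 and compound 3 cannot be separated here, and of the three groups only cyclobutylsulfanyl stands apart. Nothing available explains this difference between the groups.

Going by these compounds, it remains open whether the low number of compound 2 follows the sulfur atom or the four-membered ring. Cyclobutyloxy or a plain cyclobutyl group on the carbonyl carbon would separate the two, and an amine there is also untested in the compounds shown.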